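Side-chain swaps on the shared core: toward compound 3

A few compounds are considered here, and "the series" means these few. Any claim that something is new, unique, unknown or untested is made for them only; others in the source may bear on it.

The series keeps the core of compound 1 `O=C(CN(c1ncnc2c1ncn2C1CCCCO1)C1CC1)N[C@@H](CC(=O)OCc1ccccc1)C(=O)OCc1ccccc1` and varies the group on a saturated chain carbon, two bonds along the chain from an amide-type nitrogen and a carbonyl carbon. In a functional assay on the whole organism (Tail, strain ICR) with Mus musculus as the target, in the tail flick test, with a stated time of 30 min, at a dose of 25 umol/kg by the oral route (on this read-out lower numbers stand for a weaker effect and higher numbers for a stronger effect at the one dose given), compound 1 gives 31.8%. Among the compounds with values here, compound 2 `CC(C)C[C@H](NC(=O)CN(c1ncnc2c1ncn2C1CCCCO1)C1CC1)C(=O)OCc1ccccc1` carries isopropyl in place of benzyloxycarbonyl at that place, and in this assay compound 2 gives 26.2%, the lowest of the two numbers so far, with compound 1 nearest and within the scatter. Within the data shown here, the single step measured at this place, a number 5.6 percentage points lower from compound 1 to compound 2 (within the scatter), stayed within the scatter. Compound 3 `CSCC[C@H](NC(=O)CN(c1ncnc2c1ncn2C1CCCCO1)C1CC1)C(=O)OCc1ccccc1` differs from compound 2 by (methylsulfanyl)methyl in place of isopropyl on a saturated chain carbon, two bonds along the chain from an amide-type nitrogen and a carbonyl carbon. Because a number 5.6 percentage points lower from compound 1 to compound 2 (within the scatter) stayed flat, no step beyond the scatter is expected in this assay for compound 3, so a step of about a number 0.8 percentage points higher from compound 2 to compound 3 (within the scatter) is expected. Compound 3 is therefore estimated to give 27%, with a range from 12% to 45%.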

Compound 3, a percentage reported as activity, at one dose (the size of the read-out at that dose, not a potency): 30%
Estimate against measurement, compound 3: 3 percentage points below; measured number inside the range.
By their numbers in this assay, from the lowest: compounds 2, 3 and 1 (each within the scatter of the next).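

In this assay the sulfur-bearing (methylsulfanyl)methyl in place of isopropyl gives a number 3.8 percentage points higher from compound 2 to compound 3 (within the scatter) and the same group in place of benzyloxycarbonyl gives a number 1.8 percentage points lower from compound 1 to compound 3 (within the scatter) at this position. The position has now taken a chain group containing sulfur as well as the all-carbon isopropyl and benzyloxycarbonyl without any listed step leaving the scatter, so the flat result is no longer confined to a single swap. It also shows that swapping isopropyl for a group with a hydrogen-bond acceptor and the same number of heavy atoms leaves the read-out within the scatter, and no measurement on hand accounts for this.

The compounds shown leave open whether a free carboxylic acid, an amine or a longer chain at this place would give a step beyond the scatter. They also leave open whether any group here can separate from the three values now in hand.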